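The source may hold more compounds than are shown below. What is called first, only, known or untested is meant among the compounds shown, and "the series" means these compounds.

Among the measured compounds shown here, compound 1 `Clc1ccc(CN2CCC(CCOC(c3ccccc3)c3ccccc3)CC2)cc1Cl` stands as the higher of the two numbers so far: in an assay on cell membranes for binding affinity to sodium-dependent dopamine transporter (Rattus norvegicus) (on this read-out higher numbers stand for weaker inhibition and lower numbers for stronger inhibition), compound 1 gives 85.7 nM, while compound 2 `c1ccc(C(OCCC2CCN(Cc3cccnc3)CC2)c2ccccc2)cc1` gives 48.6 nM. For the measured compounds named here, the only step that bears on the new compound is a 1.8-fold lower number from compound 1 to compound 2 (0.25 log units; within the scatter), an exchange of the aromatic group at the same place. Compound 3 `Nc1ccc(CN2CCC(CCOC(c3ccccc3)c3ccccc3)CC2)cc1` differs from compound 1 by 4-aminophenyl in place of 3,4-dichlorophenyl on a saturated chain carbon bound to an amine nitrogen in a ring. Going by the values given here, since the one comparable exchange stayed within the scatter, compound 3 is expected to move only modestly, a 1.3-fold higher number from compound 1 to compound 3 (0.11 log units; within the scatter). Compound 3 is therefore estimated at 110 nM, with a range from 35 nM to 350 nM.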

Compound 3, half-maximal inhibitory concentration: 101 nM
Compound 3: the middle estimate sits 1.1-fold (0.04 log units) above what was measured; low and high end bracket the measured number.
By their numbers in this assay, from the lowest: compounds 2, 1 and 3 (each within the scatter of the next, the first and the last beyond it).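

Placed on a saturated chain carbon bound to an amine nitrogen in a ring, 4-aminophenyl stays within the scatter of 3,4-dichlorophenyl (a 1.2-fold higher number from compound 1 to compound 3 (0.07 log units; within the scatter)), so in this assay this exchange of a chlorine-bearing ring for one with a hydrogen-bond donor and acceptor leaves the number nearly unmoved. Set against pyridin-3-yl, the same group gives the first step here beyond the scatter, though a modest one (a 2.1-fold higher number from compound 2 to compound 3 (0.32 log units; beyond the scatter)). No evidence is available to explain either step.
As far as these compounds go, whether a 4-hydroxyphenyl, a 4-chlorophenyl or a 4-acetamidophenyl group would give a number apart from these remains open.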